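A few compounds are considered here, and "the series" means these few. Any claim that something is new, unique, unknown or untested is made for them only; others in the source may bear on it.

Three compounds built on the same core, a chalcone-like chain bearing a fluorophenyl-substituted ring, have been tested in a functional assay on MCF7 cells (Homo sapiens) for cytotoxicity, read by sulforhodamine B assay, with a stated time of 48 h; on this read-out higher numbers stand for weaker inhibition and lower numbers for stronger inhibition. Compound 1 `COc1ccc(/C=C/C(=O)c2cccc(-c3cccc(F)c3)c2)cc1OC` gives 4620 nM in this assay. Compound 2 `COc1ccc(/C=C/C(=O)c2cccc(-c3cccc(F)c3)c2)cc1O` was also prepared, but in this assay compound 2 is recorded as "not determined" (no result reported), so no number is available for it. Compound 3 `O=C(/C=C/c1cccc(Br)c1)c1cccc(-c2cccc(F)c2)c1` gives 12700 nM in this assay, the highest of the two numbers available; its nearest neighbour is compound 1, whose number is lower by a gap that lies beyond the usual scatter of repeated measurements.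

The next step leads from compound 3 to compound 4 `COc1ccccc1/C=C/C(=O)c1cccc(-c2cccc(F)c2)c1`, which has not yet been measured in this assay. The change is 2-methoxyphenyl in place of 3-bromophenyl on a double-bonded chain carbon bound to a double-bonded chain carbon. Among the measured compounds shown here, no pair of measured compounds differing in only one place is available to show how such a change plays out here, so the expectation rests on the two numbers at hand. A modest move toward stronger inhibition is expected, with the step of a 2.1-fold lower number from compound 3 to compound 4 (0.33 log units; beyond the scatter) likely to lie near the edge of the scatter. Compound 4 is therefore expected to give about 6000 nM in this assay, plausibly between 2000 nM and 18000 nM.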

Compound 4, half-maximal inhibitory concentration: 18900 nM
Beside the measured number, compound 4's estimate is 3.2-fold (0.50 log units) below it, and the stated range ends below it.
By their numbers in this assay, from the lowest: compound 1; then compounds 3 and 4 (each within the scatter of the next).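

In this assay, among the compounds shown here, 2-methoxyphenyl in place of 3-bromophenyl on a double-bonded chain carbon bound to a double-bonded chain carbon is the first one-place change that can be read, and it amounts to a 1.5-fold higher number from compound 3 to compound 4 (0.17 log units; within the scatter). At this position, then, this exchange of one substituted phenyl group for another gives two compounds that this read-out cannot tell apart, even though the entering group has one hydrogen-bond acceptor and the leaving group has none. Nothing available explains why these two compounds read alike.

One step cannot show whether other groups at this position would also read alike, such as a phenyl ring carrying an amine or a carboxylic acid. It also leaves open whether a longer chain in place of the methoxy group, such as ethoxy, would give a number beyond the scatter.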